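The compounds below may be only part of what the source reports. "The series", "measured", "known", "first", "only" and "open" are said of these compounds alone.

Compound 1 `CCCCCNc1cc(Oc2c(OC)cc3cc(C#N)ccc3c2OC)nc(Nc2ccc(C#N)cc2)n1`: > 125000 nM
Compound 2 `COc1cc2cc(C#N)ccc2c(OC)c1Oc1cc(NC(C)(C)C)nc(Nc2ccc(C#N)cc2)n1`: > 125000 nM

Both entries are limits of the assay, not numbers. From the compounds shown here alone, in an ADME assay on MT4 cells (Homo sapiens) for cytotoxicity, read by MTT assay, with a stated time of 5 days (on this read-out higher numbers stand for lower toxicity in this test and lower numbers for higher toxicity in this test), compound 2 gives > 125000 nM, so its exact place on the scale is unknown. Among the compounds with values here, the same holds for the only other measured compound, and the evidence so far is the limit of > 125000 nM in this assay, at which 2 of the 2 values shown sit.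

Compound 3 `CCC(CC)Nc1cc(Oc2c(OC)cc3cc(C#N)ccc3c2OC)nc(Nc2ccc(C#N)cc2)n1` has pentan-3-yl in place of tert-butyl on a nitrogen on an aromatic ring. Within the data shown here, the one measured step that bears on this change is a step that the two limits leave unreadable from compound 1 to compound 2, which swaps pentyl for tert-butyl at that nitrogen and gives no usable size. No shift beyond the scatter is therefore expected in this assay, and another limit is the likeliest report. The expected change is a number no higher from compound 2 to compound 3 (the limit leaves the size open). For compound 3 the estimate is 125000 nM, with an expected range of 60000 nM to 250000 nM.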

Compound 3, half-maximal cytotoxic concentration: > 125000 nM
Compound 3: a limit, no number; the forecaster's own chance of this, stated with the estimate: 80%; the middle value lies on the limit itself.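

Within the data shown here, compound 1, compound 2 and compound 3 are each reported only as a limit in this assay, and no step among them can be read. The compounds shown leave open where each true value lies, and whether pentyl, tert-butyl and pentan-3-yl differ at all.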